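The compounds below may be only part of what the source reports. "The series", "measured", "known", "first", "only" and "open" are said of these compounds alone.

Measured so far in a physicochemical assay for solubility, read by HPLC, at pH 2; a higher number here means a more soluble compound, a lower number a less soluble compound:
Compound 1, `CCN1CCC2(CC1)CC(=O)c1ccc3ccccc3c1O2`, gives >= 80000 nM, a limit of the assay rather than a number.
Compound 2, `c1ccc2c3c(ccc2c1)CCC1(CCNCC1)O3`, gives 40000 nM.
Compound 3, `O=C1CC2(CCNCC2)Oc2c1ccc1ccccc21`, gives >= 80000 nM, again a limit of the assay.

Compound 3 and compound 1 differ by ethyl in place of hydrogen on an amine nitrogen in a ring. The step that the two limits leave unreadable from compound 3 to compound 1 cannot be read, because both ends sit at the limit of >= 80000 nM in this assay, at which 2 of the 3 values shown sit. Compound 4, `CCN1CCC2(CCc3ccc4ccccc4c3O2)CC1`, is not yet measured; it differs from compound 2 by ethyl in place of hydrogen on an amine nitrogen in a ring, the same change. The difference between the core of compound 2 and the core of compound 3 is not broken down here. Among the compounds with values here, compound 2 holds the only number among the three values. Since the measured step gives no readable size, the expectation for compound 4 rests on compound 2 at 40000 nM, and the step from it is expected to be no change at the digits printed from compound 2 to compound 4 (within the scatter). Compound 4 is therefore estimated at 40000 nM, between 15000 nM and 80000 nM.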

Compound 4, solubility: <= 10000 nM
Compound 4: only a limit was reported (the forecaster's own chance of this, stated with the estimate: 30%); at least 4.0-fold (0.60 log units) between middle value and limit.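

In this assay, ethyl in place of hydrogen on an amine nitrogen in a ring gives an at least 4.0-fold lower number from compound 2 to compound 4 (0.60 log units; beyond the scatter), so on the core of compound 2 the change clearly lowers the number. On these data alone, compound 4 gives <= 10000 nM, which is a limit of the assay and not a number, so the full size of the step stays unknown. Whether the step carries over to the core of compound 3 is not shown, because compound 3 and compound 1 both sit at a limit: the limit of >= 80000 nM in this assay, at which 2 of the 4 values shown sit.

The compounds shown therefore give one core with a readable direction and no comparison between cores. They also leave open how methyl, a longer chain such as propyl, or an acetyl group on the same nitrogen would compare with ethyl.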